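Solubility notes: cyclic urea in place of the amide chain

The source may hold more compounds than are shown below. What is called first, only, known or untested is meant among the compounds shown, and "the series" means these compounds.

Measured so far, in a physicochemical assay for solubility, in phosphate buffer, measured as kinetic solubility; a higher number here means a more soluble compound, a lower number a less soluble compound:
- compound 1, `CC(C)NC(=O)CC(c1ccc(-c2ccc3cccc(F)c3c2)[nH]c1=O)C(C)C`: 18000 nM
- compound 2, `CCn1ncc2c(F)cc(-c3ccc(C(CC)(CC)c4nnc(C)[nH]4)c(=O)[nH]3)cc21`: 26900 nM

Within the data shown here, only two compounds carry a number in this assay. Compound 1 has the lower of the two, and compound 2 has the nearer (and only) neighbour; the two values lie within the scatter of each other, so no order between them is claimed. Among the measured compounds shown here, no step between measured compounds is recorded, and compound 2 shares no single-point change with either of the others, so its value stands on its own.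

The step followed here goes from compound 1 to compound 3, `CC(C)C(c1ccc(-c2ccc3cccc(F)c3c2)[nH]c1=O)N1CCNC1=O`. The change is this one: 2-oxoimidazolidin-1-yl in place of (isopropylcarbamoyl)methyl on a saturated chain carbon bound to an aromatic carbon and a saturated chain carbon. The shared core of compound 1 stays as it is; only the group on that saturated chain carbon is exchanged, and what leaves and what enters each carry one hydrogen-bond donor and one acceptor.

For the measured compounds named here, with no comparable step on record, the expectation for a 1.2-fold higher number from compound 1 to compound 3 (0.09 log units; within the scatter) is a step of no size beyond the scatter, in either direction. Compound 3 is therefore estimated at 22000 nM, with a range from 9000 nM to 50000 nM.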

Compound 3, solubility: 24900 nM
Compound 3: middle estimate off by 1.1-fold (0.05 log units), on the low side, within the range that was stated.
By their numbers in this assay, from the lowest: compounds 1, 3 and 2 (each within the scatter of the next).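

In this assay, among these compounds, putting 2-oxoimidazolidin-1-yl in place of (isopropylcarbamoyl)methyl on a saturated chain carbon bound to an aromatic carbon and a saturated chain carbon gives a 1.4-fold higher number from compound 1 to compound 3 (0.14 log units; within the scatter), the first step on record at this position. This position therefore takes a five-membered non-aromatic ring with 2 hetero atoms as well as a group with no ring, and compound 1 at 18000 nM and compound 3 at 24900 nM cannot be told apart in this assay, with the hydrogen-bond donor and acceptor counts the same in the two groups. No accompanying measurement offers an explanation for this result.

As far as these compounds go, whether a primary amine, a carboxylic acid or a longer chain on this same saturated chain carbon would give a step beyond the scatter remains open. Among the compounds shown here, also open is whether the same exchange of (isopropylcarbamoyl)methyl for 2-oxoimidazolidin-1-yl would give a step of similar size on a different core, since only this one pair, sharing the core of compound 1, carries the change.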